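This account rests on a few compounds, and the source may have more. Where it says the series, first, only, none or still open, it means among the compounds named here.

Compound 1 `COc1ccc(OC)c(/C=N/c2c(C#N)ncn2-c2ccc(F)cc2)c1` and compound 2 `N#Cc1ncn(-c2ccc(F)cc2)c1/N=C/c1ccc([N+](=O)[O-])cc1` share a five-membered core that carries a cyano group and an imine-linked aryl arm; how the two cores differ is not broken down here. In a functional assay on MDA-MB-231 cells (Homo sapiens) for antiproliferative activity, read by MTT assay, with a stated time of 48 h (on this read-out higher numbers stand for weaker inhibition and lower numbers for stronger inhibition), compound 1 gives 12300 nM, and in this assay compound 2 gives 13400 nM, two numbers within the scatter of each other. Compound 3 `COc1ccc(OC)c(/C=N/c2c(C#N)ncn2Cc2ccc(F)cc2)c1` arises from compound 1 by 4-fluorobenzyl in place of 4-fluorophenyl on an aromatic nitrogen, and in this assay compound 3 gives 17600 nM, a step of a 1.4-fold higher number from compound 1 to compound 3 (0.16 log units; within the scatter). Compound 4 `N#Cc1ncn(Cc2ccc(F)cc2)c1/N=C/c1ccc([N+](=O)[O-])cc1` arises from compound 2 by the same change, (4-fluorobenzyl in place of 4-fluorophenyl on an aromatic nitrogen), at the same place. Because that change gave only a 1.4-fold higher number from compound 1 to compound 3 (0.16 log units; within the scatter), the step is expected to be a 1.4-fold higher number from compound 2 to compound 4 (0.15 log units; within the scatter). Compound 4 is therefore estimated at 19000 nM in this assay, most likely between 9000 nM and 40000 nM.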

Compound 4, half-maximal inhibitory concentration: 3440 nM
Estimate against measurement, compound 4: 5.5-fold (0.74 log units) above, and the stated range ends above it.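

In this assay, 4-fluorobenzyl in place of 4-fluorophenyl on an aromatic nitrogen gives a 3.9-fold lower number from compound 2 to compound 4 (0.59 log units; beyond the scatter), a modest gain in inhibition. This change therefore does not carry over unaltered from one core to the other: the same change on two cores in this assay, a 1.4-fold higher number (0.16 log units; within the scatter) from compound 1 to compound 3 and a 3.9-fold lower number (0.59 log units; beyond the scatter) from compound 2 to compound 4, 5.6-fold (0.75 log units) apart, beyond the scatter of two such steps

Among these compounds, with only one pair on each core, these compounds show that the outcome of the change depends on the core, but not which part of the core is responsible or how a third core would respond. Going by these compounds, it remains open which difference between the two cores matters. On these data alone, it is also open how a longer chain carrying the 4-fluorophenyl, or a simple methyl, would behave on that same nitrogen.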